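Swapping a styryl arm for a directly attached tolyl

The source may hold more compounds than are shown below. What is called first, only, known or untested is meant among the compounds shown, and "the series" means these compounds.

Measured so far:
Compound 1, `COC(=O)/C=C/c1cccc(N(Cc2ccc(-c3ccc(N(C)C)cc3)cc2)C(=O)NC(C)C)c1`, gives 162 nM in an assay on isolated protein with Bile acid receptor (Homo sapiens) as the target; a lower number here means that less compound is needed, a higher number that more compound is needed for the effect.
Compound 2, `COC(=O)/C=C/c1cccc(N(Cc2ccc(/C=C/C(=O)OC(C)(C)C)cc2)C(=O)NC(C)C)c1`, gives 212 nM in this assay.
Compound 3, `COC(=O)/C=C/c1cccc(N(Cc2ccc(/C=C/c3cccc(F)c3)cc2)C(=O)NC(C)C)c1`, gives 467 nM in this assay.

Compound 3 has the highest number of the three: the step of a 2.2-fold higher number from compound 2 to compound 3 (0.34 log units; beyond the scatter) and the step of a 2.9-fold higher number from compound 1 to compound 3 (0.46 log units; beyond the scatter) both lie beyond the scatter, so compound 3 needs the most compound of this small set.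

Compound 4, `COC(=O)/C=C/c1cccc(N(Cc2ccc(-c3cccc(C)c3)cc2)C(=O)NC(C)C)c1`, differs from compound 3 in one place: 3-methylphenyl in place of 2-(3-fluorophenyl)ethenyl on an aromatic carbon. The change removes the ethenyl link and puts a substituted phenyl directly on the ring, in the same manner as in compound 1.

The step of a 2.9-fold higher number from compound 1 to compound 3 (0.46 log units; beyond the scatter) is the one that bears most on this, since it runs in the opposite direction: from a directly attached phenyl to a styryl arm, the number rose modestly. The step of a 2.2-fold higher number from compound 2 to compound 3 (0.34 log units; beyond the scatter) adds that the fluorophenyl-bearing arm gave the highest number. Reversing toward a directly attached phenyl is therefore expected to lower the number modestly, about a 2.3-fold lower number from compound 3 to compound 4 (0.37 log units; beyond the scatter). For compound 4 a value of 200 nM is estimated, within a range of 80 nM to 500 nM.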

Compound 4, half-maximal effective concentration: 1330 nM
Compound 4: middle estimate off by 6.7-fold (0.82 log units), on the low side, outside the stated range (above it).
By their numbers in this assay, from the lowest: compounds 1 and 2 (each within the scatter of the next); then compound 3; then compound 4.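

In this assay, attaching a phenyl ring directly at this aromatic carbon does not by itself give a low number, as removing the ethenyl link gives a 2.8-fold higher number from compound 3 to compound 4 (0.45 log units; beyond the scatter) and 3-methylphenyl does not match the earlier arms. What the attached ring carries appears to count, with an 8.2-fold higher number from compound 1 to compound 4 (0.91 log units; beyond the scatter) as the largest of the new steps and a 6.3-fold higher number from compound 2 to compound 4 (0.80 log units; beyond the scatter) showing that 3-methylphenyl also compares poorly with 2-(tert-butoxycarbonyl)ethenyl. The data shown offer no measurement that explains these rises.

Compound 1 and compound 4 differ both in the group on the attached phenyl and in where that group sits, so these two contributions cannot be separated. Also open, from the compounds shown here alone, is how a directly attached phenyl with no substituent, or one carrying a carboxylic acid or a methoxy group, would compare.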